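A few compounds are considered here, and "the series" means these few. Any claim that something is new, unique, unknown or untested is made for them only; others in the source may bear on it.

Series notes. Compound 1 `O=C1/C(=C/c2ccncc2)CN(S(=O)(=O)c2ccc([N+](=O)[O-])cc2)C/C1=C\c1ccccc1F` gives in an ADME assay on L02 cells (Homo sapiens) for cytotoxicity, read by MTT assay, with a stated time of 24 h (a higher number here means a weaker inhibitor, a lower number a stronger inhibitor), a reading of 18400 nM. Compound 2 `O=C1/C(=C/c2ccncc2)CN(S(=O)(=O)c2ccc(C(F)(F)F)cc2)C/C1=C\c1ccccc1F` carries the change trifluoromethyl in place of nitro on an aromatic carbon and gives 18600 nM in this assay; the step is a 1.0-fold higher number from compound 1 to compound 2 (0.00 log units; within the scatter). Compound 3 `O=C1/C(=C/c2ccncc2)CN(S(=O)(=O)c2ccc([N+](=O)[O-])cc2)C/C1=C\c1ccccc1C(F)(F)F` has a core that differs from that of compound 1 by trifluoromethyl in place of fluoro on an aromatic carbon. In this assay compound 3 gives 18600 nM, a step of a 1.0-fold higher number from compound 1 to compound 3 (0.00 log units; within the scatter). Compound 4 `O=C1/C(=C/c2ccncc2)CN(S(=O)(=O)c2ccc(C(F)(F)F)cc2)C/C1=C\c1ccccc1C(F)(F)F`, not yet measured, is reached from compound 3 by trifluoromethyl in place of nitro on an aromatic carbon. This is the same change as the one already seen among the measured compounds, its surroundings being described in the same words, and there it made a 1.0-fold higher number from compound 1 to compound 2 (0.00 log units; within the scatter). With the three readings all lying within the scatter of one another, and the same change having moved the reading by nothing beyond that scatter, compound 4 is expected to give 18600 nM in this assay. The expected step is no change at the digits printed from compound 3 to compound 4 (within the scatter). This expectation rests on compound 1 and compound 2 and the step of a 1.0-fold higher number from compound 1 to compound 2 (0.00 log units; within the scatter) between them. The expected range for compound 4 runs from 12000 nM to 29000 nM.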

Compound 4, half-maximal inhibitory concentration: 13800 nM
Estimate against measurement, compound 4: 1.3-fold (0.13 log units) above; low and high end bracket the measured number.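

In this assay, trifluoromethyl in place of nitro gives a 1.3-fold lower number from compound 3 to compound 4 (0.13 log units; within the scatter), and this step agrees with the one seen for the same change on the core of compound 1: the same change on two cores in this assay, a 1.0-fold higher number (0.00 log units; within the scatter) from compound 1 to compound 2 and a 1.3-fold lower number (0.13 log units; within the scatter) from compound 3 to compound 4, 1.4-fold (0.13 log units) apart, within the scatter of two such steps

Trifluoromethyl in place of fluoro gives a 1.3-fold lower number from compound 2 to compound 4 (0.13 log units; within the scatter), and this step likewise agrees with its earlier counterpart: the same change on two cores in this assay, a 1.0-fold higher number (0.00 log units; within the scatter) from compound 1 to compound 3 and a 1.3-fold lower number (0.13 log units; within the scatter) from compound 2 to compound 4, 1.4-fold (0.13 log units) apart, within the scatter of two such steps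

Each change therefore leaves the reading within the scatter on both cores where it can be followed, but these pairs give no reliable size for either change and do not show that the same would hold on any further core in the series.

On these data alone, it remains open whether an amine, a carboxylic acid or a longer chain in place of the nitro or trifluoromethyl group would move the reading beyond the scatter. Also open, as far as these compounds go, is whether the agreement between steps would persist with a wider spread of readings, since all the steps here lie within the scatter.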